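The source may report more compounds than this note shows. Statements on the series, on what has been measured and on what is new or still open speak of the compounds shown alone.

The compounds here share one core and were tested in an assay on CHO cells for binding affinity to Alpha-2C adrenergic receptor (Homo sapiens), read by radioligand binding; on this read-out higher numbers stand for weaker inhibition and lower numbers for stronger inhibition. Compound 1 `COc1ccc(S(C)(=O)=O)c(NCC2=NCCN2)c1` carries a methoxy group and a methylsulfonyl group on its aromatic ring. In this assay compound 1 gives < 5020 nM, which is a limit of the assay rather than a measured number. Compound 2 `CS(=O)(=O)c1cc(F)ccc1NCC1=NCCN1` likewise gives < 5020 nM in this assay, again only a limit. Within the data shown here, compound 3 `COc1ccc(SC)c(NCC2=NCCN2)c1` gives 603 nM in this assay, the single plain number among the three. Among the measured compounds shown here, the only step between measured compounds that differ in one place, a step that the limit leaves unreadable from compound 1 to compound 3, cannot be sized because the limit of < 5020 nM in this assay, at which 2 of the 3 values shown sit, hides the value of compound 1.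

Compound 4 `CS(=O)(=O)c1ccc(Cl)cc1NCC1=NCCN1` has not yet been measured. It differs from compound 1 by chloro in place of methoxy on an aromatic carbon. For the measured compounds named here, no measured step touches this particular change; the one step on record concerns the methylsulfonyl group instead, and even that one is unreadable. The expectation for compound 4 therefore rests on the limit of compound 1 and the values of the neighbouring compounds, nothing more. Compound 4 is expected to come in near 1500 nM, within a range from 150 nM to 6000 nM. The step that the limit leaves unreadable from compound 1 to compound 4 implied by this estimate is expected to be modest, though it cannot be checked against a limit.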

Compound 4, inhibition constant: 4790 nM
The estimate for compound 4 lay 3.2-fold (0.50 log units) below the measured number, within the range that was stated.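

Compound 1 is known only as a limit of the assay, so the change from methoxy to chloro that leads to compound 4 gives no step that can be read: the limit of < 5020 nM in this assay, at which 2 of the 4 values shown sit.

What the compounds shown leave open is the true value of compound 1 and, with it, how much chloro in place of methoxy changes the result in this assay.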